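Swapping propyl for phenyl on a butyramide inhibitor

The source may report more compounds than this note shows. Statements on the series, on what has been measured and on what is new or still open speak of the compounds shown alone.

Compound 1 `COc1cc(/C=C/C(=O)c2cccc(NC(=O)c3cc(Cl)cc(Cl)c3)c2)ccc1O`: 4.83 ug/mL
Compound 2 `COc1cc(/C=C/C(=O)c2cccc(NC(=O)c3ccco3)c2)ccc1O`: 5.46 ug/mL
Compound 3 `CCCC(=O)Nc1cccc(C(=O)/C=C/c2ccc(O)c(OC)c2)c1`: 1.43 ug/mL

All three values come from a functional assay on B16 cells (Mus musculus) for inhibition; a higher number here means a weaker inhibitor, a lower number a stronger inhibitor. Compound 3 has the lowest number, making it the strongest inhibitor of the three. Compound 4 `COc1cc(/C=C/C(=O)c2cccc(NC(=O)c3ccccc3)c2)ccc1O` carries phenyl in place of propyl on a carbonyl carbon. Going by the values given here, two measured steps bear on this change, since both put propyl in place of a ring group: a 3.4-fold lower number from compound 1 to compound 3 (0.53 log units; beyond the scatter) and a 3.8-fold lower number from compound 2 to compound 3 (0.58 log units; beyond the scatter). Both are modest but beyond the scatter, whereas a 1.1-fold higher number from compound 1 to compound 2 (0.05 log units; within the scatter) shows the two ring groups within it. Phenyl is therefore expected to reverse much of that gain, and the expected step is a 3.1-fold higher number from compound 3 to compound 4 (0.50 log units; beyond the scatter). The estimated value for compound 4 is 4.5 ug/mL, with an expected range of 2.2 ug/mL to 9 ug/mL.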

Compound 4, half-maximal inhibitory concentration: 0.82 ug/mL
The estimate for compound 4 lay 5.5-fold (0.74 log units) above the measured number; the measured number lies below the stated range.
By their numbers in this assay, from the lowest: compounds 4 and 3 (each within the scatter of the next); then compounds 1 and 2 (each within the scatter of the next).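

Phenyl in place of propyl gives a 1.7-fold lower number from compound 3 to compound 4 (0.24 log units; within the scatter) in this assay so a ring on this carbonyl carbon does not by itself cost strength. The weaker numbers of compound 1 and compound 2 therefore go with those particular rings: phenyl in place of 3,5-dichlorophenyl gives a 5.9-fold lower number from compound 1 to compound 4 (0.77 log units; beyond the scatter) and phenyl in place of furan-2-yl gives a 6.7-fold lower number from compound 2 to compound 4 (0.82 log units; beyond the scatter) in this series. No measurement shown explains these differences. Still open, going by these compounds, is whether a longer chain, or an amine on the phenyl ring, would keep the number this low.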